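A methoxy group enters the anilino ring of compound 1

The compounds below may be only part of what the source reports. "The series", "measured", "known", "first", "only" and "open" are said of these compounds alone.

Measured so far in a functional assay on NCI-H460 cells (Homo sapiens) for antiproliferative activity, read by sulforhodamine B assay, with a stated time of 48 h; on this read-out higher numbers stand for lower toxicity in this test and lower numbers for higher toxicity in this test:
Compound 1, `Cc1nc(SCC(=O)Nc2nc(-c3ccc(Cl)cc3)cs2)n(Nc2ccccc2)c1C`, gives 82100 nM.
Compound 2, `Cc1ccc(Nn2c(SCC(=O)Nc3nc(-c4ccccc4)cs3)nc(C)c2C)cc1`, gives 83300 nM.

Both compounds share the same core and differ from each other in two places at once, so no single step can be read between them; their two values lie within the scatter of each other, and neither can be called more or less toxic than the other in this assay. Compound 1 has the lower of the two numbers shown, but that difference means nothing here.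

Compound 3, `COc1ccc(Nn2c(SCC(=O)Nc3nc(-c4ccc(Cl)cc4)cs3)nc(C)c2C)cc1`, is compound 1 with one change: methoxy in place of hydrogen on an aromatic carbon. Within the data shown here, no pair of measured compounds shows this change on its own, so nothing measured points in either direction. With the two measured values so close together, the step from compound 1 to compound 3 in this assay is expected to stay within the scatter: a 1.0-fold lower number from compound 1 to compound 3 (0.01 log units; within the scatter). Compound 3 is therefore estimated at 80000 nM, with a range from 40000 nM to 160000 nM.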

Compound 3, concentration lethal to 50% of the cells: > 100000 nM
Compound 3 was reported as a limit; the forecaster's own chance of this, stated with the estimate: 15%; at least 1.2-fold (0.09 log units) between middle value and limit.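

In this assay compound 3 gives > 100000 nM, which is a limit of the assay and not a number. Placing methoxy on the anilino ring, on the ring carbon para to a large group, can therefore be read only as a floor: an at least 1.2-fold higher number from compound 1 to compound 3 (0.08 log units; that floor lies within the scatter). This is the first look at a change on this ring with everything else in compound 1 held fixed, and it shows that methoxy here does not bring the number down, though the floor is too small to show a true increase, and the top of the test range limits what can be read: the limit of > 100000 nM in this assay, at which 1 of the 3 values shown sits.

As far as these compounds go, how far compound 3 really lies from compound 1 stays unknown, as does whether the methoxy step would look the same with another group on the far phenyl ring in place of the chlorine of compound 1. Also open, from the compounds shown here alone, is whether a different group at this ring position, such as an amine or a carboxylic acid, would give a value that can be read as a number in this assay.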